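A few compounds are considered here, and "the series" means these few. Any claim that something is new, unique, unknown or untested is made for them only; others in the source may bear on it.

Of the compounds shown here, three built on one shared core have been measured in a functional assay on HCC827 cells (Homo sapiens) for inhibition, read by fluorescence, with a stated time of 72 h; a lower number here means a stronger inhibitor of growth, a higher number a weaker inhibitor of growth. Compound 1 `CCCCCCn1cnc2c(Nc3ccc(O)cc3)nc(N[C@H]3CC[C@H](N)CC3)nc21` gives 24700 nM, the highest of the three numbers. Compound 2 `CC(C)CCn1cnc2c(NCc3cccc(Cl)c3)nc(N[C@H]3CC[C@H](N)CC3)nc21` gives 16700 nM, a number that lies within the scatter of compound 1. Compound 3 `CCCCn1cnc2c(Nc3cccc(Cl)c3)nc(N[C@H]3CC[C@H](N)CC3)nc21` gives 7200 nM, and its gap to compound 1 lies beyond the scatter. No two of these three compounds differ in only one place, so no single step can be read off among them.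

Compound 4 `CCCCCCn1cnc2c(Nc3ccc(Cl)cc3)nc(N[C@H]3CC[C@H](N)CC3)nc21` has not yet been measured in this assay. It differs from compound 1 in one place: chloro in place of hydroxy on an aromatic carbon. Compound 3, which also carries a chloro group, gives 7200 nM, a clearly lower number than compound 1, though it differs from compound 1 in more than one place. A moderate step toward a lower number is therefore expected, a 2.2-fold lower number from compound 1 to compound 4 (0.35 log units; beyond the scatter), while an outcome within the scatter remains possible. Compound 4 is estimated at 11000 nM, with a range from 3500 nM to 30000 nM.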

Compound 4, concentration for 50% growth inhibition: 11700 nM
For compound 4 the middle estimate is 1.1-fold (0.03 log units) below the measured one, within the range that was stated.
By their numbers in this assay, from the lowest: compounds 3, 4, 2 and 1 (each within the scatter of the next, the first and the last beyond it).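

With the rest of the structure unchanged, chloro in place of hydroxy on an aromatic carbon, para to a large group, gives a 2.1-fold lower number from compound 1 to compound 4 (0.32 log units; beyond the scatter) in this assay. For the compounds shown here, this is the first change at this position that can be read on its own, and it shows that the number responds to this exchange, although the step is modest. Nothing here accounts for the step, even though a hydrogen-bond donor and acceptor leave with the hydroxy group and the chloro group brings neither.

Going by these compounds, whether other groups at this position, such as an amine, methoxy or a carboxylic acid, would move the number further remains open. Compound 2 and compound 3 differ from compound 4 in more than one place, so steps to them cannot be read.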